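From a free sulfanyl to (4-fluorobenzyl)sulfanyl

This account rests on a few compounds, and the source may have more. Where it says the series, first, only, none or still open, it means among the compounds named here.

- Compound 1 `COc1ccc(-n2c(S)nnc2-c2cc(OC)c(OC)c(OC)c2)cc1`: > 60000 nM (a limit)
- Compound 2 `COc1cc(-c2nnc(S)n2-c2ccc(N(C)C)cc2)cc(OC)c1OC`: > 60000 nM (a limit)

Both results come from a functional assay on HT-29 cells (Homo sapiens) for inhibition, read by MTT assay, with a stated time of 48 h; on this read-out lower numbers stand for stronger inhibition and higher numbers for weaker inhibition. Compound 2 has no exact value in this test, only the limit > 60000 nM. Compound 1 offers no firmer reference point, as the record shows: the limit of > 60000 nM in this assay, at which 2 of the 2 values shown sit.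

The next compound, compound 3 `COc1cc(-c2nnc(SCc3ccc(F)cc3)n2-c2ccc(N(C)C)cc2)cc(OC)c1OC`, differs from compound 2 in one place: 4-fluorobenzyl in place of hydrogen on a sulfur. Here 4-fluorobenzyl stands in place of hydrogen on a sulfur, so sulfanyl becomes (4-fluorobenzyl)sulfanyl.

Going by the values given here, only one measured step exists: a step that the two limits leave unreadable from compound 1 to compound 2. It put dimethylamino in place of methoxy on an aromatic carbon, which is a different change, and it has no readable size to carry over. The expectation for the new step is therefore only a loose one.

Among the compounds with values here, compound 2 gives > 60000 nM, a limit, so the only readable change in this assay would be toward a lower number, meaning stronger inhibition, and that direction is expected. The estimated change is an at least 15-fold lower number from compound 2 to compound 3 (1.17 log units; beyond the scatter). For compound 3 the estimated value is 4000 nM. The expected range for compound 3 runs from 200 nM to 50000 nM.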

Compound 3, half-maximal inhibitory concentration: 44300 nM
For compound 3 the middle estimate is 11-fold (1.04 log units) below the measured one, within the range that was stated.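

Going by these compounds alone, on the sulfur, 4-fluorobenzyl in place of hydrogen gives the first step of readable size in this assay and the step is an at least 1.3-fold lower number from compound 2 to compound 3 (0.13 log units; that floor lies within the scatter) while the earlier step between the free sulfanyl compounds cannot be read. Within the data shown here, compound 3 also brings the first exact value, so this position now has a number against which later changes on the sulfur could be compared. Compound 2 has only a limit, so the step is a floor and its true size remains unknown, because the reference compound sits at that limit: the limit of > 60000 nM in this assay, at which 2 of the 3 values shown sit.

What the compounds shown leave open is whether the gain in readability belongs to the 4-fluorobenzyl group itself or would appear with a plain benzyl, a methyl or a longer chain on the same sulfur, perhaps one ending in an amine or a carboxylic acid. Also open, as far as these compounds go, is whether (4-fluorobenzyl)sulfanyl would give a similar result with the methoxy group of compound 1 in place of the dimethylamino group of compound 3.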